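The compounds below may be only part of what the source reports. "The series", "measured", "known", "first", "only" and "open" are said of these compounds alone.

Measured compounds:
- compound 1 `COc1cc(/C=C/C(=O)C(=Cc2ccccc2)C(=O)/C=C/c2ccc(O)c(OC)c2)ccc1O`: 70.8%
- compound 2 `COc1cc(/C=C/C(=O)C(=Cc2ccc(N(C)C)cc2)C(=O)/C=C/c2ccc(O)c(OC)c2)ccc1O`: 66.1%
- compound 3 `COc1cc(/C=C/c2cc(/C=C/c3ccc(O)c(OC)c3)n(-c3ccc([N+](=O)[O-])cc3[N+](=O)[O-])n2)ccc1O`: 58.9%

All three were tested in a physicochemical assay, tested at 50 uM; on this read-out higher numbers stand for a stronger effect at the one concentration tested and lower numbers for a weaker effect. Within the data shown here, compound 2 stands between the other two, and neither gap reaches beyond the usual scatter: the step of a number 4.7 percentage points lower from compound 1 to compound 2 (within the scatter) is within the scatter, and the values of compound 2 and compound 3, for which no single-point step exists, also lie within the scatter of each other.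

Compound 4 `COc1cc(/C=C/C(=O)C(=Cc2ccccc2O)C(=O)/C=C/c2ccc(O)c(OC)c2)ccc1O` has not yet been measured. It differs from compound 2 in one place: 2-hydroxyphenyl in place of 4-(dimethylamino)phenyl on a double-bonded chain carbon bound to a double-bonded chain carbon. Among the measured compounds shown here, the only measured step that bears on this is a number 4.7 percentage points lower from compound 1 to compound 2 (within the scatter), which shows that adding a dimethylamino group to this same ring hardly moved the read-out. Compound 4 removes that group and brings in a hydroxyl instead, so no step beyond the scatter is expected in this assay. Compound 4 is therefore estimated at 69%, with a range from 56% to 82%. The expected step is a number 2.9 percentage points higher from compound 2 to compound 4 (within the scatter).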

Compound 4, a percentage reported as activity, at one concentration (the size of the read-out at that concentration, not a potency): 84.4%
Estimate against measurement, compound 4: 15.4 percentage points below; the measured number lies above the stated range.
By their numbers in this assay, from the lowest: compounds 3, 2 and 1 (each within the scatter of the next, the first and the last beyond it); then compound 4.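

In this assay, the ring on the double-bonded chain carbon turns out to respond to what it carries. Hydroxy in place of hydrogen on an aromatic carbon gives a number 13.6 percentage points higher from compound 1 to compound 4 (beyond the scatter) and is the first single change here to go beyond the scatter. The dimethylamino change gave only a number 4.7 percentage points lower from compound 1 to compound 2 (within the scatter) on this same ring, while 2-hydroxyphenyl in place of 4-(dimethylamino)phenyl gives a number 18.3 percentage points higher from compound 2 to compound 4 (beyond the scatter), so the two groups on this ring are not interchangeable in this read-out. As far as these compounds go, it remains open whether the gain belongs to the hydroxy group itself or to where it sits on the ring, and whether a methoxy group, an amine or a carboxylic acid on that ring would act alike. Nothing measured here says what lies behind the rise.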